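The compounds below may be only part of what the source reports. "The series", "measured", "known", "first", "only" and "open" are said of these compounds alone.

Three close relatives of one shared core were measured in a functional assay on CHO.K1 cells for antagonist activity at prostaglandin D2 receptor 2 (Homo sapiens), read by GTPgammaS binding, with a stated time of 1 h; on this read-out lower numbers stand for stronger inhibition and higher numbers for weaker inhibition. Compound 1 `Cc1c(Cc2ccccc2S(=O)(=O)c2cccc(Cl)c2)c2c(n1CC(=O)O)CCNC2=O` gives 4 nM. Compound 2 `COc1cccc(S(=O)(=O)c2ccccc2Cc2c3c(n(CC(=O)O)c2C)CCNC3=O)c1` gives 12 nM. Compound 3 `Cc1c(Cc2ccccc2S(=O)(=O)c2ccc(Cl)cc2)c2c(n1CC(=O)O)CCNC2=O` gives 8.5 nM. Each pair differs in a single place. The change from compound 1 to compound 2 is methoxy in place of chloro on an aromatic carbon, and it brought a 3.0-fold higher number from compound 1 to compound 2 (0.48 log units; beyond the scatter). The change from compound 1 to compound 3 is 4-chlorophenyl in place of 3-chlorophenyl on a sulfonyl sulfur, and it brought a 2.1-fold higher number from compound 1 to compound 3 (0.33 log units; beyond the scatter). Between compound 2 and compound 3 the difference is a 1.4-fold lower number from compound 2 to compound 3 (0.15 log units; within the scatter), so those two numbers cannot be told apart.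

Compound 4 `COc1ccc(S(=O)(=O)c2ccccc2Cc2c3c(n(CC(=O)O)c2C)CCNC3=O)cc1` has not yet been measured in this assay. It differs from compound 3 by methoxy in place of chloro on an aromatic carbon. This is the same kind of change as that from compound 1 to compound 2, seen once before among these compounds; the two cores differ as described under (4-chlorophenyl in place of 3-chlorophenyl on a sulfonyl sulfur), and the surroundings differ too, the earlier change sitting meta to a large group and the new one para to a large group. Among the compounds with values here, the earlier step is the only guide available here, with nothing measured to show whether the para position answers in the same way.

On the strength of compound 1 and the step of a 3.0-fold higher number from compound 1 to compound 2 (0.48 log units; beyond the scatter), the step expected from compound 3 to compound 4 in this assay is a 2.9-fold higher number from compound 3 to compound 4 (0.47 log units; beyond the scatter). Compound 4 is therefore estimated at 25 nM in this assay, with the likely span running from 10 nM to 60 nM.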

Compound 4, half-maximal inhibitory concentration: 3.9 nM
Beside the measured number, compound 4's estimate is 6.4-fold (0.81 log units) above it; the measured number lies below the stated range.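

Swapping chloro for methoxy does not carry over from one core to the other in this series, as its size and even its direction changed: the same change on two cores in this assay, a 3.0-fold higher number (0.48 log units; beyond the scatter) from compound 1 to compound 2 and a 2.2-fold lower number (0.34 log units; beyond the scatter) from compound 3 to compound 4, 6.5-fold (0.82 log units) apart, beyond the scatter of two such steps. On the core of compound 3, with the group para to a large group, the swap gave a 2.2-fold lower number from compound 3 to compound 4 (0.34 log units; beyond the scatter), and changing 3-methoxyphenyl to 4-methoxyphenyl on the sulfonyl sulfur gave a 3.1-fold lower number from compound 2 to compound 4 (0.49 log units; beyond the scatter), whereas 4-methoxyphenyl in place of 3-chlorophenyl gave a 1.0-fold lower number from compound 1 to compound 4 (0.01 log units; within the scatter), so those two numbers cannot be told apart. Within the data shown here, this shows that a step measured on one of these cores was a poor guide to the same swap on the other, but with only two such pairs it gives no general rule and does not show why the steps differ.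

The compounds shown leave open whether a fluoro, a methyl or a longer ether such as ethoxy, placed para to a large group, would fall in line with methoxy or with chloro. They also leave open whether the same reversal would appear on a core in which an amide stands in place of the carboxylic acid.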